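Series notes: benzyl piperidinol analogues in the hydrolase assay

The source may report more compounds than this note shows. Statements on the series, on what has been measured and on what is new or still open speak of the compounds shown alone.

Going by the values given here, compound 1 `COC(=O)c1ccc(N2CCC(O)(Cn3cnc4c(Br)n(C)nc4c3=O)CC2)c(Cl)c1` is the only member with a number in an assay on Sf21 cells for inhibition of ubiquitin carboxyl-terminal hydrolase 7 (Homo sapiens), read by spectrophotometry, with stated times of 30 min and 2 h (a lower number here means a stronger inhibitor, a higher number a weaker inhibitor), where compound 1 gives 157 nM. Compound 2 `N#Cc1ccc(CN2CCC(O)(Cn3cnc4c(cnn4-c4ccc(F)cc4)c3=O)CC2)cc1` has no single number there: in this assay compound 2 returns "not determined" (no result reported), so compound 2 stands nowhere on the scale shown. Compound 3 `COC(=O)c1ccc(CN2CCC(O)(Cn3cnc4c(cnn4-c4ccc(F)cc4)c3=O)CC2)c(F)c1` differs from compound 2 by 2-fluoro-4-(methoxycarbonyl)phenyl in place of 4-cyanophenyl on a saturated chain carbon bound to an amine nitrogen in a ring. Among the compounds with values here, with no measured step to rest on, the change from compound 2 to compound 3 is expected to give no shift beyond the scatter in this assay, direction unset. Compound 3 is estimated at 160 nM, between 30 nM and 1500 nM.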

Compound 3, half-maximal inhibitory concentration: 800 nM
Beside the measured number, compound 3's estimate is 5.0-fold (0.70 log units) below it; measured number inside the range.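

Compound 2 has no number, so no step can be read for the change from 4-cyanobenzyl to 2-fluoro-4-(methoxycarbonyl)benzyl in compound 3. From the compounds shown here alone, what that change does to inhibition stays open. No evidence at hand bears on the result.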